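Changing the aryl group on compound 2

A few compounds are considered here, and "the series" means these few. Any claim that something is new, unique, unknown or untested is made for them only; others in the source may bear on it.

In a functional assay on A549 cells (Homo sapiens) for cytotoxicity, read by MTT assay, with a stated time of 72 h (a lower number here means a stronger inhibitor, a higher number a weaker inhibitor), compound 1 (`COc1ccc(/C=N/NC(=O)Nc2cc3c(Nc4ccc(F)c(Cl)c4)ncnc3cc2O[C@H]2CCOC2)cc1`) gives 33100 nM. Compound 2 (`COc1ccc(/C=N/NC(=O)Nc2cc3c(Nc4ccc(F)c(Cl)c4)ncnc3cc2O[C@H]2CCOC2)c(OC)c1OC`) gives 25200 nM, which lies within the scatter of compound 1, so the two cannot be told apart. Compound 3 (`O=C(N/N=C/c1ccc(O)c(Br)c1)Nc1cc2c(Nc3ccc(F)c(Cl)c3)ncnc2cc1O[C@H]1CCOC1`) has not yet been measured. It carries 3-bromo-4-hydroxyphenyl in place of 2,3,4-trimethoxyphenyl on a carbon with a double bond to nitrogen. Among the measured compounds shown here, only one measured step changes this same place: a 1.3-fold lower number from compound 1 to compound 2 (0.12 log units; within the scatter), with 2,3,4-trimethoxyphenyl in place of 4-methoxyphenyl. For the measured compounds named here, no measured compound carries 3-bromo-4-hydroxyphenyl, so the data offer only a loose guide and support no clear direction. The step expected in this assay is a 1.1-fold lower number from compound 2 to compound 3 (0.06 log units; within the scatter), which means none beyond the scatter. Compound 3 is expected at 22000 nM, with an estimated range of 9000 nM to 50000 nM.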

Compound 3, half-maximal inhibitory concentration: 4310 nM
Beside the measured number, compound 3's estimate is 5.1-fold (0.71 log units) above it; the whole stated range lies above it.
By their numbers in this assay, from the lowest: compound 3; then compounds 2 and 1 (each within the scatter of the next).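

Changing the aryl group on the carbon with a double bond to nitrogen can shift the number in this assay, which the earlier pair of methoxy-bearing compounds did not reveal. With 3-bromo-4-hydroxyphenyl, the result is a 5.8-fold lower number from compound 2 to compound 3 (0.77 log units; beyond the scatter) and, against the other methoxy-bearing group, a 7.7-fold lower number from compound 1 to compound 3 (0.89 log units; beyond the scatter), so both steps lie beyond the scatter while the rest of the molecule stays the same. The entering group brings a bromine and a hydrogen-bond donor and has no methoxy group, but no measurement here explains the drop.

Among the compounds shown here, whether the bromine or the hydroxyl matters more stays open, as the only compound carrying either group carries both. On these data alone, how an amine or a carboxylic acid on this aryl ring would read also remains unknown.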